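This account rests on a few compounds, and the source may have more. Where it says the series, first, only, none or still open, it means among the compounds named here.

In a functional assay with Oryctolagus cuniculus as the target (on this read-out higher numbers stand for weaker inhibition and lower numbers for stronger inhibition), the measured compounds read as follows:
Compound 1 `COc1ccc(-c2nc(C(=O)N=C(N)N)sc2-c2ccc(OC)cc2)cc1` gives > 100 nM (a limit, not a number)
Compound 2 `COc1ccc(-c2nc(C(=O)N3CCOCC3)sc2-c2ccc(OC)cc2)cc1` gives < 10 nM (a limit, not a number)
Compound 3 `COc1ccc(-c2nc(C(=O)N3CCCCC3)sc2-c2ccc(OC)cc2)cc1` gives > 1000 nM (a limit, not a number)

The value of compound 3 is > 1000 nM and that is a limit, not a number. Compared with compound 3, compound 4 `COc1ccc(-c2nc(C(=O)N3CCCCC3CCO)sc2-c2ccc(OC)cc2)cc1` has 2-hydroxyethyl in place of hydrogen on a saturated ring carbon, next to the ring nitrogen (2-hydroxyethyl in place of hydrogen on a saturated ring carbon).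

The measured step closest to this change is an at least 100-fold higher number from compound 2 to compound 3 (2.00 log units; beyond the scatter) with piperidin-1-yl in place of morpholin-4-yl, and it is large. Two other steps change the group on the carbonyl carbon: an at least 10-fold lower number from compound 1 to compound 2 (1.00 log units; beyond the scatter) is at least modest, while a step that the two limits leave unreadable from compound 1 to compound 3 cannot be read.

Compound 4 keeps the ring of compound 3 but regains an oxygen, now in a side chain and not in the ring. Among the measured compounds shown here, no measured compound carries a side chain on this ring, so the forecast is uncertain. A partial return towards stronger inhibition is expected, and that expectation rests on an at least 100-fold higher number from compound 2 to compound 3 (2.00 log units; beyond the scatter) alone. The expected change is an at least 3.3-fold lower number from compound 3 to compound 4 (0.52 log units; beyond the scatter) towards a lower number. The estimate for compound 4 is 300 nM within an expected range from 30 nM to 3000 nM until the measurement arrives.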

Compound 4, half-maximal inhibitory concentration: 45 nM
Compound 4: middle estimate off by 6.7-fold (0.82 log units), on the high side; low and high end bracket the measured number.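

In this assay, putting 2-hydroxyethyl on a saturated ring carbon, next to the ring nitrogen, gives an at least 22-fold lower number from compound 3 to compound 4 (1.34 log units; beyond the scatter), so this position accepts a side chain, and the change recovers much of what was lost when piperidin-1-yl replaced morpholin-4-yl. The recovery is only partial: 2-(2-hydroxyethyl)piperidin-1-yl in place of morpholin-4-yl still leaves an at least 4.5-fold higher number from compound 2 to compound 4 (0.65 log units; beyond the scatter), while the comparison with the group on the carbonyl carbon of compound 1 gives an at least 2.2-fold lower number from compound 1 to compound 4 (0.34 log units; beyond the scatter). One end of each of these steps is a limit and not a number, so each size is a minimum, as with compound 3: the limit of > 1000 nM in this assay, at which 1 of the 4 values shown sits.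

As far as these compounds go, what remains open is whether the gain needs the oxygen of the side chain or only the added carbon chain, a question that a plain ethyl group, a 2-aminoethyl group or a longer 3-hydroxypropyl chain on the same ring carbon would help to answer. Also open, from the compounds shown here alone, is how 2-hydroxyethyl would read on the morpholine ring of compound 2, which already gives a much lower number than compound 3.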